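Swapping cyclobutyl for tert-butyl on a urea series

The source may report more compounds than this note shows. Statements on the series, on what has been measured and on what is new or still open speak of the compounds shown alone.

Values measured in a functional assay (strain AB) with Danio rerio as the target, read by microscopy, with a stated time of 1 h (on this read-out lower numbers stand for an effect already at smaller amounts and higher numbers for an effect only at larger amounts of compound), are these
Compound 1 (`CCN1CCc2c(sc(NC(=O)Nc3ccccc3)c2C(N)=O)C1`) gives > 25000 nM as a limit of the assay, not a number
Compound 2 (`NC(=O)c1c(NC(=O)Nc2ccc(Cl)cc2)sc2c1CCN(CC1CCC1)C2`) gives 1360 nM as its measured value
Compound 3 (`NC(=O)c1c(NC(=O)Nc2ccc(Cl)cc2)sc2c1CCN(CCCNC(=O)CCc1cccc3ccccc13)C2`) gives 110 nM as its measured value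

Compound 2 has the higher of the two real numbers, and it sits above compound 3 by more than the usual scatter. Compound 4 (`CC(C)(C)CN1CCc2c(sc(NC(=O)Nc3ccc(Cl)cc3)c2C(N)=O)C1`) keeps the shared core and carries tert-butyl in place of cyclobutyl on a saturated chain carbon bound to an amine nitrogen in a ring, a change that also reads as cyclobutylmethyl to neopentyl. Among the compounds with values here, no measured pair shows this change. With compound 2 at 1360 nM as the starting point, no step beyond the scatter is expected in this assay in either direction. The expected change is (a 1.1-fold higher number from compound 2 to compound 4 (0.04 log units; within the scatter)) and stays small. For compound 4 the estimated value is 1500 nM with an expected range from 500 nM to 5000 nM when it is measured.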

Compound 4, half-maximal effective concentration: 5560 nM
Compound 4: the middle estimate sits 3.7-fold (0.57 log units) below what was measured; the measured number lies above the stated range.
By their numbers in this assay, from the lowest: compound 3; then compound 2; then compound 4. At a limit, above all of these: compound 1.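

In this assay, tert-butyl in place of cyclobutyl gives a 4.1-fold higher number from compound 2 to compound 4 (0.61 log units; beyond the scatter). Both groups hold 4 heavy atoms, all carbon, and only cyclobutyl has a ring, so at this position a swap that keeps the heavy-atom count can still move the number beyond the scatter. The data shown offer no measurement that explains this step.

Going by these compounds, whether cyclopropyl or cyclopentyl in the same place would follow cyclobutyl or tert-butyl remains open. So does the effect of a carboxylic acid there.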